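The source may hold more compounds than are shown below. What is called first, only, known or untested is meant among the compounds shown, and "the series" means these compounds.

Compound 1 `C[C@@H]1CN(c2ncccc2C(F)(F)F)CCN1C(=O)Nc1ccc(C(F)(F)F)cc1`: 17 nM in a functional assay for antagonist activity at transient receptor potential cation channel subfamily V member 1 (Homo sapiens), read by FLIPR; a lower number here means a stronger inhibitor, a higher number a weaker inhibitor.
Compound 2 `CC(C)(C)c1ccc(NC(=O)c2ccc(-c3ncccc3NS(C)(=O)=O)cc2)cc1`: 152 nM in this assay.

Of these two numbers, compound 2 has the higher one, so it is the weaker inhibitor, and its gap to compound 1 lies well beyond the usual scatter. Compound 3 `CC(C)(C)c1ccc(NC(=O)c2ccc(-c3ncccc3-c3nnco3)cc2)cc1` has not been measured. It differs from compound 2 in one place: 1,3,4-oxadiazol-2-yl in place of methanesulfonamido on an aromatic carbon. Among the measured compounds shown here, no measured pair shows what this change does, so the expectation rests on compound 2 alone. The expected step in this assay is small, if anything toward a weaker inhibitor: a 1.4-fold higher number from compound 2 to compound 3 (0.16 log units; within the scatter). Compound 3 is estimated at 220 nM, within a range of 60 nM to 800 nM.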

Compound 3, half-maximal inhibitory concentration: 91 nM
Beside the measured number, compound 3's estimate is 2.4-fold (0.38 log units) above it; the range from low to high includes it.
By their numbers in this assay, from the lowest: compound 1; then compounds 3 and 2 (each within the scatter of the next).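

In this assay, placing 1,3,4-oxadiazol-2-yl where methanesulfonamido stood gives a step within the scatter (a 1.7-fold lower number from compound 2 to compound 3 (0.22 log units; within the scatter)), so compound 2 and compound 3 cannot be told apart. This aromatic carbon therefore accepts a five-membered aromatic ring as well as an open sulfonamide group, and the hydrogen-bond donor of methanesulfonamido is not needed to keep this level of inhibition in this pair. Nothing available explains why the two groups read alike. From the compounds shown here alone, whether a smaller group such as an amine, or a carboxylic acid, would fare the same at this carbon stays open.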